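Working notes on compounds 1 to 4

The source may report more compounds than this note shows. Statements on the series, on what has been measured and on what is new or still open speak of the compounds shown alone.

Measured so far, in a functional assay on MCF7 cells (Homo sapiens) for cytotoxicity, read by MTT assay, with a stated time of 72 h; a lower number here means a stronger inhibitor, a higher number a weaker inhibitor:
- compound 1 `COc1ccccc1Nc1nc(SCc2ccc(C(F)(F)F)cc2)nc2ccccc12`: compound 1 gives > 50000 nM, a limit of the assay.
- compound 2 `Cc1ccccc1Nc1nc(SCc2ccc(C(F)(F)F)cc2)nc2ccccc12`: compound 2 gives 37500 nM.
- compound 3 `Cc1ccc(Nc2nc(SCc3ccc(C(F)(F)F)cc3)nc3ccccc23)cc1`: compound 3 gives > 50000 nM, again a limit of the assay.

The change methoxy in place of methyl on an aromatic carbon gives an at least 1.3-fold higher number from compound 2 to compound 1 (0.12 log units; that floor lies within the scatter), with the limit of > 50000 nM in this assay, at which 2 of the 3 values shown sit, capping how far it can be read. Compounds 2 and 3 share their atoms but differ in the core as 4-methylphenyl in place of 2-methylphenyl on a nitrogen on an aromatic ring, and that move gives an at least 1.3-fold higher number from compound 2 to compound 3 (0.12 log units; that floor lies within the scatter).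

Compound 4 `COc1ccc(Nc2nc(SCc3ccc(C(F)(F)F)cc3)nc3ccccc23)cc1` is not yet measured. It differs from compound 3 by methoxy in place of methyl on an aromatic carbon. This is the same kind of change as from compound 2 to compound 1, but the place differs: there ortho to a large group, here para to a large group. Compound 3 sits at a limit of the assay. Compound 4 is therefore expected near 60000 nM, an expected step that the limit leaves unreadable from compound 3 to compound 4 beside an at least 1.3-fold higher number from compound 2 to compound 1 (0.12 log units; that floor lies within the scatter).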

Compound 4, half-maximal inhibitory concentration: 47200 nM
Beside the measured number, compound 4's estimate is 1.3-fold (0.10 log units) above it; the range from low to high includes it.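

In this assay, methoxy in place of methyl gives an at least 1.0-fold lower number from compound 3 to compound 4 (0.02 log units; that floor lies within the scatter), while the moves from the other two compounds give a 1.3-fold higher number from compound 2 to compound 4 (0.10 log units; within the scatter) and an at least 1.0-fold lower number from compound 1 to compound 4 (0.02 log units; that floor lies within the scatter). Set beside the earlier case, this shows no clear effect of the change on either core, and it does not show whether the change carries from one core to the other: the same change on two cores in this assay, an at least 1.3-fold higher number (0.12 log units; that floor lies within the scatter) from compound 2 to compound 1 and an at least 1.0-fold lower number (0.02 log units; that floor lies within the scatter) from compound 3 to compound 4; the limit leaves it open whether they differ No step here can be sized beyond the scatter, and the values stay close to this limit: the limit of > 50000 nM in this assay, at which 2 of the 4 values shown sit.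

From the compounds shown here alone, it remains open whether an amine or a carboxylic acid in place of the methoxy would give a value clear of the limit. Going by these compounds, a longer chain at that place is equally open.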